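From Methoxy to Fluoro: Expecting Compound 4's Growth Inhibition

The source may report more compounds than this note shows. Statements on the series, on what has been measured and on what is new or still open speak of the compounds shown alone.

Three compounds were measured in a functional assay on HT-29 cells (Homo sapiens) for inhibition, read by sulforhodamine B assay, with a stated time of 48 h; on this read-out higher numbers stand for weaker inhibition of growth and lower numbers for stronger inhibition of growth:
compound 1 `CC1=CC[C@H](C(C)(C)N=C=S)CC1` gives the limit > 100000 nM, a limit of this assay, not a number.
compound 2 `CC1=CC[C@H](C(C)(C)NC(=S)NN)CC1` gives the limit > 100000 nM, likewise a limit.
compound 3 `COc1ccc(/C=N/NC(=S)NC(C)(C)[C@H]2CC=C(C)CC2)cc1` gives 33600 nM.

Among the measured compounds shown here, compound 3 therefore stands as the only numeric value among the three, the others sitting at the limit of > 100000 nM in this assay, at which 2 of the 3 values shown sit. For the measured compounds named here, the sole step between measured neighbours, a step that the two limits leave unreadable from compound 1 to compound 2, is unreadable and concerns the chain, not the aromatic ring, so no measured step bears on compound 4 `CC1=CC[C@H](C(C)(C)NC(=S)N/N=C/c2ccc(F)cc2)CC1`, which differs from compound 3 by fluoro in place of methoxy on an aromatic carbon. With nothing measured to guide it, the step of no change at the digits printed from compound 3 to compound 4 (within the scatter) is expected to stay within the scatter. Compound 4 is accordingly estimated at 33600 nM, in a range from 12000 nM to 95000 nM.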

Compound 4, concentration for total growth inhibition: > 100000 nM
Compound 4 ended at the assay's limit; the forecaster's own chance of this, stated with the estimate: 25%; middle value at least 2.9-fold (0.47 log units) from the limit.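

Fluoro in place of methoxy, on an aromatic carbon para to a large group, gives an at least 2.9-fold higher number from compound 3 to compound 4 (0.47 log units; beyond the scatter), the first readable step in this series and one that falls on the aromatic ring, not the chain. From the compounds shown here alone, compound 4 gives > 100000 nM, which is a limit and not a number, so the full size of the step stays unknown. Only compound 3 keeps a number, the others sitting together: the limit of > 100000 nM in this assay, at which 3 of the 4 values shown sit.

Going by these compounds, it remains open how a hydroxy, an ethoxy or a chlorine on that same aromatic carbon would read. The same holds for an unsubstituted phenyl.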